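From 2-methylpyrimidin-5-yl to 2-fluorophenyl on the shared core

A few compounds are considered here, and "the series" means these few. Any claim that something is new, unique, unknown or untested is made for them only; others in the source may bear on it.

In an in vitro ADME assay on microsomes from liver (Homo sapiens) for metabolic stability (a lower number here means slower removal, a higher number faster removal of the compound), compound 1 `Cc1ncc(Cc2nc(-c3nc(C(F)(F)F)n[nH]3)n3ccccc23)cn1` gives < 8 mL.min-1.g-1, which is a limit of the measurement and not a number. Compound 3 `Cc1ncc(Cc2nc(-c3nc(C(F)(F)F)n[nH]3)n3cccc(F)c23)cn1` also gives a limit, < 8 mL.min-1.g-1. The data therefore stop at the limit of < 8 mL.min-1.g-1 in this assay, at which 2 of the 3 values shown sit.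

Compound 4 `Fc1ccccc1Cc1nc(-c2nc(C(F)(F)F)n[nH]2)n2ccccc12` is still unmeasured. It keeps the core of compound 1 and differs by 2-fluorophenyl in place of 2-methylpyrimidin-5-yl on a saturated chain carbon bound to an aromatic carbon.

Little bears on this change. For the measured compounds named here, the only measured step is a step that the two limits leave unreadable from compound 1 to compound 3, and it puts fluoro in place of hydrogen on an aromatic carbon, a different change that gives no size to carry over. The 2-fluorobenzyl also appears in compound 2 `Fc1ccccc1Cc1nc(-c2nc(C(F)(F)F)n[nH]2)c2cccnn12`, whose entry in this assay reads "not determined" (no result reported), so it offers no guide.

A reported number for compound 4 can only lie on the upper side of the limit that compound 1 shows at < 8 mL.min-1.g-1. The expected step is an at least 1.7-fold higher number from compound 1 to compound 4 (0.24 log units; that floor lies within the scatter), a modest rise in this assay, though another result at the limit remains possible. Compound 4 is estimated at 14 mL.min-1.g-1, with an expected range of 8 mL.min-1.g-1 to 35 mL.min-1.g-1.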

Compound 4, intrinsic clearance in microsomes: 72 mL.min-1.g-1
For compound 4 the middle estimate is 5.1-fold (0.71 log units) below the measured one; the measured number lies above the stated range.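

Among the compounds shown, an at least 9.0-fold higher number from compound 1 to compound 4 (0.95 log units; beyond the scatter) is the only step that can be read in this assay and the fluoro step on the shared core, from compound 1 to compound 3, cannot be read. This step lies beyond the usual scatter, so the ring carried on the saturated chain carbon is not a neutral choice here: replacing 2-methylpyrimidin-5-yl by 2-fluorophenyl clearly moves the read-out toward faster removal. The true size may be larger still, since the step is only a floor set by a limit, not by a number, on the side of compound 1: the limit of < 8 mL.min-1.g-1 in this assay, at which 2 of the 4 values shown sit.

This single pair removes two ring nitrogens and brings in a fluorine at once, so it cannot show which part of the swap goes with the rise. Going by these compounds, how a plain phenyl, a pyridine ring or a chain carrying a morpholine would read at this place stays open, as does whether 2-fluorophenyl gives the same rise on other cores.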